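The source may hold more compounds than are shown below. What is called first, only, known or untested is meant among the compounds shown, and "the series" means these compounds.

In a functional assay on the whole organism for inhibition, with Mus musculus as the target (on this read-out higher numbers stand for an effect only at larger amounts of compound and lower numbers for an effect already at smaller amounts), compound 1 (`CCOC(=O)Nc1cccc2c1CN(C)CC2c1ccccc1`) gives 3.2 mg/kg. Its chloro relative, compound 2 (`CCOC(=O)Nc1cccc2c1CN(C)CC2c1ccc(Cl)cc1`), gives 4.8 mg/kg, and its fluoro relative, compound 3 (`CCOC(=O)Nc1cccc2c1CN(C)CC2c1ccc(F)cc1`), gives 3.5 mg/kg. These three stand together with no real separation, as the data show a 1.5-fold higher number from compound 1 to compound 2 (0.18 log units; within the scatter), a 1.1-fold higher number from compound 1 to compound 3 (0.04 log units; within the scatter) and a 1.4-fold lower number from compound 2 to compound 3 (0.14 log units; within the scatter).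

Compound 4 (`CC(C)NCC(=O)Nc1cccc2c1CN(C)CC2c1ccccc1`) keeps the core of compound 1 but changes a different part of the molecule: (isopropylamino)methyl in place of ethoxy on a carbonyl carbon. In other words, ethoxycarbonyl gives way to ((isopropylamino)methyl)carbonyl.

The measured steps offer only weak guidance here. Each of them swaps hydrogen or a halogen on an aromatic carbon, and none touches the carbonyl carbon where the new change falls. They show that those aromatic swaps stayed within the scatter, but they say nothing directly about replacing ethoxy. Going by these compounds, with no measured neighbour at this place, both the size and the direction of the step remain open. A moderate move toward a higher number is the cautious expectation, and the range has to stay wide.

This amounts to an expected step of a 2.2-fold higher number from compound 1 to compound 4 (0.34 log units; beyond the scatter). For compound 4 the estimated dose is 7 mg/kg, with an expected range from 2 mg/kg to 25 mg/kg.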

Compound 4, dose for half-maximal effect: 14 mg/kg
For compound 4 the middle estimate is 2.0-fold (0.30 log units) below the measured one, and the stated range covers the measured number.
By their numbers in this assay, from the lowest: compounds 1, 3 and 2 (each within the scatter of the next); then compound 4.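

In this assay, swapping hydrogen or halogen on the aromatic carbon stayed within the scatter, whereas changing the group on the carbonyl carbon produces a clear shift, a 4.4-fold higher number from compound 1 to compound 4 (0.64 log units; beyond the scatter), so a larger dose is needed for the same effect. This position therefore responds to what it carries, at least for this change, although the step is a single comparison and swaps several features at once: ethoxy, with its oxygen and no hydrogen-bond donor, gives way to the larger (isopropylamino)methyl, with a nitrogen and one hydrogen-bond donor. Nothing here has been measured that would explain the shift, so it can only be recorded as an observation.

The compounds shown cannot separate the contribution of the amine from that of the added size, and a plain alkyl group such as isopropyl on the carbonyl carbon, or a dimethylamino group in place of the isopropylamino group, would help to pull these apart. Going by these compounds, it also remains open whether a chloro or fluoro group on the aromatic ring would stay within the scatter when combined with (isopropylamino)methyl on the carbonyl carbon.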